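Replacing the Aryl Methyl with Nitro in Compound 1

A few compounds are considered here, and "the series" means these few. Any claim that something is new, unique, unknown or untested is made for them only; others in the source may bear on it.

The series rests on a shared core that carries an acetyl group, a methyl group and a hydrazine link to a second aromatic ring. For the measured compounds named here, compound 1 `CC(=O)c1c(NNc2ccc(C)cc2)cc(C)oc1=O` holds a methyl on that ring; in a functional assay on the whole organism (strain Swiss albino) with Mus musculus as the target, with stated times of 30 min and 10 min, at a dose of 50 mg/kg by the oral route (on this read-out higher numbers stand for more inhibition at the one dose given (going by the name of the read-out) and lower numbers for less inhibition), compound 1 gives 70.2%, the highest of the two numbers measured so far. Compound 2 `COc1ccc(NNc2cc(C)oc(=O)c2C(C)=O)cc1` carries a methoxy in its place and gives 59.2%, so that a number 11 percentage points lower from compound 1 to compound 2 (beyond the scatter), a modest fall that lies beyond the usual scatter. Compound 3 `CC(=O)c1c(NNc2ccc([N+](=O)[O-])cc2)cc(C)oc1=O` is the next member: nitro in place of methyl on an aromatic carbon. Only the methoxy step bears on this change, and it shows that exchanging the methyl on this aromatic carbon for another group lowered inhibition by a modest amount. Going by the values given here, no step with a nitro group has been measured, so the direction for compound 3 is taken from that single comparison. Compound 3 is therefore expected to give 60%, within a range of 42% to 78%. That estimate amounts to a number 10.2 percentage points lower from compound 1 to compound 3 (beyond the scatter), a step expected to be modest and downward, though a result within the scatter of compound 1 cannot be ruled out.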

Compound 3, a percentage reported as inhibition, in the whole organism at one dose (the size of the read-out at that dose, not a potency): 47.3%
Beside the measured number, compound 3's estimate is 12.7 percentage points above it, and the stated range covers the measured number.
By their numbers in this assay, from the lowest: compound 3; then compound 2; then compound 1.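

In this assay nitro in place of methyl on this aromatic carbon, para to a large group, gives a number 22.9 percentage points lower from compound 1 to compound 3 (beyond the scatter) and so the loss seen earlier with methoxy is not particular to that one group. Nitro in place of methoxy on the same carbon gives a number 11.9 percentage points lower from compound 2 to compound 3 (beyond the scatter) and this shows that the two replacing groups do not count alike here: methyl, methoxy and nitro give three separate levels of inhibition at the one dose, with compound 1 highest and compound 3 lowest. Nothing at hand accounts for why the numbers fall in this order.

From the compounds shown here alone, what an amine, a carboxylic acid, a chlorine atom or a longer chain such as ethyl would do on this aromatic carbon stays open, and so does whether any group at all can match or pass methyl there. Going by these compounds, the three compounds also share the one dose and differ only at this carbon, so it remains open whether the same order would hold at other doses or with changes elsewhere on the shared core.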